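This account rests on a few compounds, and the source may have more. Where it says the series, first, only, none or still open, it means among the compounds named here.

Going by the values given here, in a functional assay on NCI-H1993 cells (Homo sapiens) for inhibition, read by CCK-8 assay, with a stated time of 72 h (a lower number here means a stronger inhibitor, a higher number a weaker inhibitor), compound 1 `CC(NC/N=C/c1cnn(C)c1)c1ccc2ncccc2c1` gives 197 nM and compound 2 `CC(NC/N=C/c1cnn(CCO)c1)c1ccc2ncccc2c1` gives 148 nM, so compound 2 stands within the scatter of its only neighbour. Compound 3 `CC(NC/N=C/C1=CCNCC1)c1ccc2ncccc2c1`, not yet measured, differs from compound 2 by a group of 6 heavy atoms (5 carbon, 1 nitrogen; one six-membered non-aromatic ring with 1 hetero atom) in place of a group of 8 heavy atoms (5 carbon, 2 nitrogen, 1 oxygen; one five-membered aromatic ring with 2 hetero atoms), on a carbon with a double bond to nitrogen. Among the compounds with values here, the one measured step, a 1.3-fold lower number from compound 1 to compound 2 (0.12 log units; within the scatter), lies within the scatter and leaves the aromatic ring in place, so it gives only weak guidance for replacing that ring. A modest move toward a weaker number is expected, shown as the estimated 2.4-fold higher number from compound 2 to compound 3 (0.37 log units; beyond the scatter). For compound 3 the estimated value is 350 nM, with an expected range of 90 nM to 1300 nM.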

Compound 3, half-maximal inhibitory concentration: 2660 nM
Estimate against measurement, compound 3: 7.6-fold (0.88 log units) below, outside the stated range (above it).
By their numbers in this assay, from the lowest: compounds 2 and 1 (each within the scatter of the next); then compound 3.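

In this assay the carbon with a double bond to nitrogen does not accept every ring: replacing 1-(2-hydroxyethyl)-1H-pyrazol-4-yl with the six-membered non-aromatic ring gives an 18-fold higher number from compound 2 to compound 3 (1.25 log units; beyond the scatter) and is a large loss. Against the five-membered aromatic ring of compound 1 the same replacement gives a 14-fold higher number from compound 1 to compound 3 (1.13 log units; beyond the scatter) and is again large, whereas the earlier change on that ring stayed within the scatter. Nothing measured here bears on the reason for this loss. On these data alone, whether a phenyl or pyridine ring at this carbon would match compound 2 remains open, as does the effect of a methyl group on the ring nitrogen of compound 3.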